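This account rests on a few compounds, and the source may have more. Where it says the series, first, only, none or still open, it means among the compounds named here.

Measured so far in a physicochemical assay for lipophilicity, using the shake flask method, in phosphate buffer, measured as octanol-water partition, with a stated time of 24 h, at pH 7.4, tested at 100 uM; a lower number here means a more polar compound, a higher number a more lipophilic compound:
compound 1 `Cc1cc(OCCCS(C)(=O)=O)cc(C)c1-c1cccc(COc2ccc(CCC(=O)O)cc2)c1`: 3.75
compound 2 `COc1cc(C)c(-c2cccc(COc3ccc(S(=O)(=O)CC(=O)O)cc3)c2)c(C)c1`: 2.45
compound 3 `CCOc1cc(C)c(-c2cccc(COc3ccc(S(=O)(=O)CC(=O)O)cc3)c2)c(C)c1`: 2.86

Compound 3, at 2.86, stands second highest of the three, above compound 2 and below compound 1.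

The next compound is compound 4 `Cc1cc(OCC2CC2)cc(C)c1-c1cccc(COc2ccc(S(=O)(=O)CC(=O)O)cc2)c1`. It carries cyclopropyl in place of methyl on a saturated chain carbon bound to an oxygen on an aromatic ring, so ethoxy becomes cyclopropylmethoxy: cyclopropyl in place of methyl on a saturated chain carbon bound to an oxygen on an aromatic ring.

Within the data shown here, only one measured step bears on this change. At that same place, methyl replaced hydrogen, and this assay gave a number 0.41 log units higher from compound 2 to compound 3 (beyond the scatter). That modest rise came with a smaller addition of carbon than the one made here. Among the measured compounds shown here, no measured compound carries cyclopropyl at this place, so the evidence is thin.

A rise of similar or slightly larger size is therefore expected, and the estimated step is a number 0.49 log units higher from compound 3 to compound 4 (beyond the scatter). For compound 4 the expected value is 3.35, with an estimated range from 3 to 3.7.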

Compound 4, distribution coefficient: 3.46
Compound 4: middle estimate off by 0.11 log units, on the low side, within the range that was stated.
By their numbers in this assay, from the lowest: compound 2; then compound 3; then compounds 4 and 1 (each within the scatter of the next).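

In this assay, cyclopropyl in place of methyl on a saturated chain carbon bound to an oxygen on an aromatic ring gives a number 0.60 log units higher from compound 3 to compound 4 (beyond the scatter), so a second enlargement of the group at this place also raises the number. Taken as a whole, cyclopropyl in place of hydrogen gives a number 1.01 log units higher from compound 2 to compound 4 (beyond the scatter), and these three compounds, which differ only here, rise in the order hydrogen, methyl, cyclopropyl. Nothing measured here explains this rise.

Going by these compounds, what a propyl group in place of cyclopropyl would give remains open, and that comparison would help separate the effect of the ring from that of the carbon count. Also open, on these data alone, is whether an amine or a hydroxyl group on this chain would reverse the direction.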